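Replacing the 6-carboxypyridin-2-yl group: clearance notes

The source may report more compounds than this note shows. Statements on the series, on what has been measured and on what is new or still open speak of the compounds shown alone.

In an in vitro ADME assay on microsomes from liver (Homo sapiens) for metabolic stability (a lower number here means slower removal, a higher number faster removal of the compound), compound 1 `Cc1ccc(NC(=O)[C@H](CC2CCCC2)n2cnc(C(F)(F)F)c2)nc1` gives > 120 mL/min/kg as a limit of the assay. Compound 3 `O=C(Nc1ccc(S(=O)(=O)O)cn1)[C@H](CC1CCCC1)n1cnc(C(F)(F)F)c1` gives < 8 mL/min/kg as a limit too. Compound 2 `O=C(O)c1cccc(NC(=O)[C@H](CC2CCCC2)n2cnc(C(F)(F)F)c2)n1` gives < 8 mL/min/kg as a limit and stands at the limit of < 8 mL/min/kg in this assay, at which 2 of the 3 values shown sit, without a number of its own. Compound 4 `O=C(O)Cn1ccc(NC(=O)[C@H](CC2CCCC2)n2cnc(C(F)(F)F)c2)n1` carries 1-(carboxymethyl)-1H-pyrazol-3-yl in place of 6-carboxypyridin-2-yl on an amide-type nitrogen. The steps of an at least 15-fold lower number from compound 1 to compound 2 (1.17 log units; beyond the scatter) and an at least 15-fold lower number from compound 1 to compound 3 (1.17 log units; beyond the scatter) bear on this change and both are large, beyond the scatter. The step of an at least 15-fold lower number from compound 1 to compound 2 (1.17 log units; beyond the scatter) ended in a carboxy-bearing group and compound 4 also bears one, so no step beyond the scatter is expected in this assay. The expected change is a number no lower from compound 2 to compound 4 (the limit leaves the size open) in this estimate. Compound 4 is estimated at 8 mL/min/kg with 5 mL/min/kg to 20 mL/min/kg as the expected range.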

Compound 4, clearance: < 8 mL/min/kg
Compound 4 was reported as a limit; the forecaster's own chance of this, stated with the estimate: 65%; the middle value lies on the limit itself.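

In this assay, 1-(carboxymethyl)-1H-pyrazol-3-yl on the amide-type nitrogen gives an at least 15-fold lower number from compound 1 to compound 4 (1.17 log units; beyond the scatter), so this position tolerates a five-membered aromatic ring with 2 hetero atoms as well as a six-membered one without loss of the low read-out. With compound 4, the carboxy group also reaches the low end when carried on a carboxymethyl chain rather than directly on the ring. Any step between compound 2 and compound 4 cannot be read, as both values are limits.

Any order among compound 2, compound 3 and compound 4 stays hidden: the limit of < 8 mL/min/kg in this assay, at which 3 of the 4 values shown sit. Whether a methyl ester or primary amide in place of the carboxylic acid on the carboxymethyl chain would hold the low end remains open.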